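Bromo in Place of Trifluoromethoxy, Before the Number Arrives

A few compounds are considered here, and "the series" means these few. Any claim that something is new, unique, unknown or untested is made for them only; others in the source may bear on it.

Measured so far:
compound 1, `CC(c1ccc(-c2ccccc2)c(F)c1)c1nnc2n1N=C(c1ccc(OC(F)(F)F)cc1)CS2`: 5400 nM in a functional assay on HCT-116 cells (Homo sapiens) for inhibition, read by sulforhodamine B assay, with a stated time of 72 h; a higher number here means a weaker inhibitor, a lower number a stronger inhibitor
compound 2, `COc1ccc2cc(C(C)c3nnc4n3N=C(c3ccc(C(F)(F)F)cc3)CS4)ccc2c1`: 10800 nM

Only these two compounds carry numbers. Compound 1 has the lower of the two values in this assay, but the value of compound 2 lies within the usual scatter of it, so the pair shows no difference that can be read as real.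

Compound 3 `CC(c1ccc(-c2ccccc2)c(F)c1)c1nnc2n1N=C(c1ccc(Br)cc1)CS2` has not yet been measured. It differs from compound 1 in one place: bromo in place of trifluoromethoxy on an aromatic carbon. Within the data shown here, no measured pair of compounds shows this change, so there is no step to lean on. Given the narrow spread between compound 1 and compound 2, the expectation is that the step to compound 3 in this assay stays within the scatter, with no clear direction. Compound 3 is therefore expected at 5000 nM, in the range 1500 nM to 16000 nM. The expected step is a 1.1-fold lower number from compound 1 to compound 3 (0.03 log units; within the scatter).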

Compound 3, half-maximal inhibitory concentration: 7100 nM
Compound 3: the middle estimate sits 1.4-fold (0.15 log units) below what was measured; the range from low to high includes it.
By their numbers in this assay, from the lowest: compounds 1, 3 and 2 (each within the scatter of the next).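

In this assay, among these compounds, the change from 4-(trifluoromethoxy)phenyl to 4-bromophenyl gives a 1.3-fold higher number from compound 1 to compound 3 (0.12 log units; within the scatter), and this is the first comparison here that isolates a single place in these compounds. At this aromatic carbon, a group of 5 heavy atoms with 1 hydrogen-bond acceptor and a single bromine atom with none therefore cannot be told apart in this read-out. Nothing available explains this outcome or shows what, if anything, the two groups have in common at this position.

Going by these compounds, whether an amine or a carboxylic acid on this aromatic carbon would move the number in this assay remains open. Compound 2 differs from compound 1 in more than one place, so the other parts of the molecule have no single-change comparison yet.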